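This account rests on a few compounds, and the source may have more. Where it says the series, first, only, none or still open, it means among the compounds named here.

Three compounds share one core and differ only in a small substituent. Compound 1 `N#Cc1cc(-c2nc3ccc(F)cc3s2)ccc1N` gives 820 nM in a functional assay on MCF7 cells (Homo sapiens) for inhibition, with a stated time of 72 h; on this read-out lower numbers stand for stronger inhibition of growth and higher numbers for weaker inhibition of growth. Compound 2 `N#Cc1cc(-c2nc3c(F)cccc3s2)ccc1N`, which carries its fluoro at another position of the fused ring, gives 180 nM in this assay, the second highest of the three numbers; the gap to compound 1 lies beyond the usual scatter. For the measured compounds named here, compound 3 `C#Cc1cc(-c2nc3c(F)cccc3s2)ccc1N` gives 110 nM in this assay, and the only single-point step among the measured compounds, a 1.6-fold lower number from compound 2 to compound 3 (0.21 log units; within the scatter), comes from putting ethynyl in place of cyano and stays within the scatter.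

Compound 4 `N#Cc1cc(-c2nc3ccccc3s2)ccc1N` is not yet measured. It arises from compound 2 by hydrogen in place of fluoro on an aromatic carbon. Going by the values given here, no measured step covers the loss of a fluoro; the values of compound 1 and compound 2 show only that where the fluoro sits matters. The expectation for compound 4 is therefore uncertain, with a modest rise as the likelier outcome, a step of a 1.9-fold higher number from compound 2 to compound 4 (0.29 log units; within the scatter). Compound 4 is estimated at 350 nM, between 120 nM and 1000 nM.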

Compound 4, concentration for 50% growth inhibition: 580 nM
Compound 4: the middle estimate sits 1.7-fold (0.22 log units) below what was measured, within the range that was stated.
By their numbers in this assay, from the lowest: compounds 3 and 2 (each within the scatter of the next); then compounds 4 and 1 (each within the scatter of the next).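

In this assay the swap of fluoro for hydrogen gives a 3.2-fold higher number from compound 2 to compound 4 (0.51 log units; beyond the scatter), the first measured sign that a fluoro on this aromatic carbon matters for growth inhibition. The same swap at the other fluoro position gives a 1.4-fold lower number from compound 1 to compound 4 (0.15 log units; within the scatter), so at that position the fluoro cannot be told apart from hydrogen. Among these compounds, then, the benefit comes from where the fluoro sits and not from simply carrying one, and no data at hand explain why.

Still open, going by these compounds, is whether only fluoro works at the position that matters, or whether a chloro, a methyl or a methoxy there would do as well. On these data alone, it is also open whether the ethynyl compound would respond to losing its fluoro in the same way.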